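The source may hold more compounds than are shown below. What is called first, only, known or untested is meant among the compounds shown, and "the series" means these compounds.

Compound 1 `Cc1cc(OCC(C)C)cc(C)c1-c1cccc(COc2ccc(OCC(=O)O)c(F)c2)c1` carries an isobutoxy group on its core. In a functional assay on CHO cells for agonist activity at Free fatty acid receptor 1 (Homo sapiens), read by FLIPR and calcium flux (a higher number here means that more compound is needed for the effect, a lower number that less compound is needed), compound 1 stands without a number, its entry reading "not determined" (no result reported). Two relatives share that core with a different ether: compound 2 `CCOc1cc(C)c(-c2cccc(COc3ccc(OCC(=O)O)c(F)c3)c2)c(C)c1`, which in this assay gives 65.9 nM, and compound 3 `CCCCOc1cc(C)c(-c2cccc(COc3ccc(OCC(=O)O)c(F)c3)c2)c(C)c1`, whose entry in this assay likewise reads "not determined" (no result reported). Compound 4 `COc1cc(C)c(-c2cccc(COc3ccc(OCC(=O)O)c(F)c3)c2)c(C)c1` has not yet been measured. It differs from compound 1 in one place: hydrogen in place of isopropyl on a saturated chain carbon bound to an oxygen on an aromatic ring. Against the one number known, compound 2, this shortening is expected to cost little, at most a step within or just beyond the usual scatter toward a higher number. Compound 4 is therefore estimated at 110 nM, with a likely range from 30 nM to 400 nM.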

Compound 4, half-maximal effective concentration: 49.7 nM
Beside the measured number, compound 4's estimate is 2.2-fold (0.35 log units) above it; measured number inside the range.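

In this assay this position now has a step that can be read: a 1.3-fold lower number from compound 2 to compound 4 (0.12 log units; within the scatter). With hydrogen in place of methyl on this saturated chain carbon, the two compounds cannot be told apart, so removing that one carbon makes no clear difference between these two short ethers. No measurement shown gives a reason for this.

Steps to compound 1 and compound 3 cannot be read, so the effect of the isobutoxy group and of a longer chain stays open. So does the effect of an amine or a cyclopropyl group at this place.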